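Cytotoxicity limits in compounds 1 to 3; compound 4 next

A few compounds are considered here, and "the series" means these few. Any claim that something is new, unique, unknown or untested is made for them only; others in the source may bear on it.

Measured so far:
compound 1 `O=C(O)c1cccc(-c2ccc(/C=C3\S/C(=N\c4ccc(F)cc4)N(c4ccc(F)cc4)C3=O)s2)c1` — > 200000 nM
compound 2 `O=C(O)c1cccc(-c2ccc(/C=C3\S/C(=N\c4ccccc4)N(c4ccc(Cl)cc4)C3=O)o2)c1` — > 200000 nM
compound 3 `O=C(O)c1cccc(-c2ccc(/C=C3\S/C(=N\c4ccccc4)N(c4ccc(F)cc4)C3=O)o2)c1` — > 200000 nM

In an ADME assay on Vero cells (Chlorocebus sabaeus) for cytotoxicity (a lower number here means that less compound is tolerated, a higher number that more compound is tolerated), compound 1 gives > 200000 nM, which is a limit of the assay and not a number. Compound 2 gives > 200000 nM in this assay, also a limit. Compound 3 gives > 200000 nM in this assay, again a limit. Compound 1 thus stands exactly where every measured value of the series sits: the limit of > 200000 nM in this assay, at which 3 of the 3 values shown sit. For the measured compounds named here, the only step between measured neighbours that differ in one place, a step that the two limits leave unreadable from compound 2 to compound 3, lies between two limits and its size is not readable.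

Compound 4 `O=C(O)c1cccc(-c2ccc(/C=C3\S/C(=N\c4ccccc4)N(c4ccc(F)cc4)C3=O)s2)c1` differs from compound 1 by hydrogen in place of fluoro on an aromatic carbon. Going by the values given here, no measured step bears directly on this change, and the single step available gives no readable size. The expectation for this assay is therefore that a step that the limit leaves unreadable from compound 1 to compound 4 amounts to no step beyond the scatter. Compound 4 is expected to give about 300000 nM in this assay, with a range from 150000 nM to 600000 nM, most likely again reported only as a limit.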

Compound 4, half-maximal cytotoxic concentration: > 200000 nM
Compound 4: no number, only a limit (the forecaster's own chance of this, stated with the estimate: 90%); the middle value does not contradict the limit.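

In this assay no step can be read between compound 1 and compound 4, as both values are limits and not numbers: the limit of > 200000 nM in this assay, at which 4 of the 4 values shown sit.

The compounds shown leave open at what concentration any of them becomes cytotoxic, and whether 4-fluorophenyl to phenyl shifts that concentration.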